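Nitro to Trifluoromethyl on the Sulfonyl Aryl Ring

The source may hold more compounds than are shown below. What is called first, only, known or untested is meant among the compounds shown, and "the series" means these compounds.

Measured compounds:
Compound 1, `O=C1/C(=C/c2ccncc2)CN(S(=O)(=O)c2ccc([N+](=O)[O-])cc2)C/C1=C\c1ccccc1F`: in an ADME assay on L02 cells (Homo sapiens) for cytotoxicity, read by MTT assay, with a stated time of 24 h (on this read-out higher numbers stand for weaker inhibition and lower numbers for stronger inhibition), compound 1 gives 18400 nM.
Compound 2, `O=C1/C(=C/c2ccncc2)CN(S(=O)(=O)c2ccc(C(F)(F)F)cc2)C/C1=C\c1ccccc1F`: compound 2 gives 18600 nM.
Compound 3, `O=C1/C(=C/c2cccnc2)CN(S(=O)(=O)c2ccc([N+](=O)[O-])cc2)C/C1=C\c1ccccc1C(F)(F)F`: compound 3 gives 15700 nM.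

Compound 4, `O=C1/C(=C/c2cccnc2)CN(S(=O)(=O)c2ccc(C(F)(F)F)cc2)C/C1=C\c1ccccc1C(F)(F)F`, has not been measured. Compound 1 and compound 2 differ by trifluoromethyl in place of nitro on an aromatic carbon, and this gave a 1.0-fold higher number from compound 1 to compound 2 (0.00 log units; within the scatter). The difference between the cores of compound 1 and compound 3 is not broken down here. Compound 3 and compound 4 differ by trifluoromethyl in place of nitro on an aromatic carbon, with the same surroundings, so it is the same change. The step from compound 3 to compound 4 is expected to be a 1.0-fold higher number from compound 3 to compound 4 (0.01 log units; within the scatter), because the earlier 1.0-fold higher number from compound 1 to compound 2 (0.00 log units; within the scatter) stayed within the scatter. Compound 4 is therefore estimated at 16000 nM, likely between 8000 nM and 32000 nM.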

Compound 4, half-maximal inhibitory concentration: 14300 nM
Compound 4: middle estimate off by 1.1-fold (0.05 log units), on the high side; the measured number falls inside the stated range.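

In this assay, trifluoromethyl in place of nitro on an aromatic carbon gives a 1.1-fold lower number from compound 3 to compound 4 (0.04 log units; within the scatter) and so makes no readable difference on this core. Set beside the earlier step, the change carries from one core to the other with no detectable difference between the two steps: the same change on two cores in this assay, a 1.0-fold higher number (0.00 log units; within the scatter) from compound 1 to compound 2 and a 1.1-fold lower number (0.04 log units; within the scatter) from compound 3 to compound 4, 1.1-fold (0.05 log units) apart, within the scatter of two such steps. Among these compounds, this shows only that the swap leaves the read-out about where it was on these two cores in this one assay; it does not show that the same would hold on other cores, and it does not explain the result.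

From the compounds shown here alone, only nitro and trifluoromethyl appear at this place, so the effect of an amine or a carboxylic acid there remains open. Going by these compounds, whether the swap would behave the same way in other cell types also remains open.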